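The compounds below may be only part of what the source reports. "The series", "measured", "known", "first", "only" and "open" are said of these compounds alone.

Measured so far in a functional assay on HepG2 cells (Homo sapiens) for cytotoxicity, read by MTT assay, with a stated time of 48 h; on this read-out higher numbers stand for weaker inhibition and lower numbers for stronger inhibition:

compound 1 `COc1cccc2[nH]cc(C3(c4c[nH]c5cccc(OC)c45)C(=O)Nc4ccccc43)c12` gives 9000 nM
compound 2 `O=C1Nc2ccccc2C1(c1c[nH]c2ccc(Cl)cc12)c1c[nH]c2ccc(Cl)cc12` gives 14600 nM
compound 3 `COc1cccc2[nH]cc(C3(c4c[nH]c5cccc(OC)c45)C(=O)Nc4ccc(F)cc43)c12` gives 18000 nM

Compound 1 and compound 3 share one core and differ in a single place, (fluoro in place of hydrogen on an aromatic carbon). This change produced a 2.0-fold higher number from compound 1 to compound 3 (0.30 log units; within the scatter), so the two values sit close together. How the core of compound 2 differs from the core of compound 1 is not broken down here. Compound 4 `O=C1Nc2ccc(F)cc2C1(c1c[nH]c2ccc(Cl)cc12)c1c[nH]c2ccc(Cl)cc12` has not yet been measured; it stands to compound 2 exactly as compound 3 stands to compound 1, through the same change, (fluoro in place of hydrogen on an aromatic carbon), at a place described in the same words. Because the earlier step was a 2.0-fold higher number from compound 1 to compound 3 (0.30 log units; within the scatter), the step from compound 2 to compound 4 is expected to be of similar size, a 1.7-fold higher number from compound 2 to compound 4 (0.23 log units; within the scatter). Compound 4 is therefore estimated at 25000 nM in this assay, most likely between 10000 nM and 60000 nM.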

Compound 4, half-maximal inhibitory concentration: 16600 nM
Beside the measured number, compound 4's estimate is 1.5-fold (0.18 log units) above it, and the stated range covers the measured number.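

In this assay, putting fluoro in place of hydrogen on an aromatic carbon of the core of compound 2 gives a 1.1-fold higher number from compound 2 to compound 4 (0.06 log units; within the scatter). Set beside the earlier step, the same change on the other core gives a step that cannot be told apart from it: the same change on two cores in this assay, a 2.0-fold higher number (0.30 log units; within the scatter) from compound 1 to compound 3 and a 1.1-fold higher number (0.06 log units; within the scatter) from compound 2 to compound 4, 1.8-fold (0.25 log units) apart, within the scatter of two such steps. The change therefore carries across these two cores in the limited sense that neither step leaves the scatter, but this does not show that fluoro has a real effect on either core or that it would behave alike on a third.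

At this place the compounds shown carry only hydrogen or fluoro. Going by these compounds, how a nitrile, an amine or a carboxylic acid there would read remains open.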